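The source may hold more compounds than are shown below. What is called first, only, known or untested is meant among the compounds shown, and "the series" means these compounds.

Measured so far, in an assay on Sf9 cells for inhibition of serine/threonine-protein kinase 4 (Homo sapiens), read by luminescence and ADP-Glo, with a stated time of 1 h, in the presence of a further agent that is not named here; on this read-out higher numbers stand for weaker inhibition and lower numbers for stronger inhibition:
Compound 1, `CC(C)CC1C(=O)N(C)c2cnc(Nc3ccc(S(N)(=O)=O)cc3)nc2N1C`, gives 77 nM.
Compound 2, `CN1C(=O)C(c2ccccc2C(F)(F)F)N(C)c2nc(Nc3ccc(S(N)(=O)=O)cc3)ncc21`, gives 56 nM.
Compound 3, `Cc1ccc(F)cc1C1C(=O)N(C)c2cnc(Nc3ccc(S(N)(=O)=O)cc3)nc2N1C`, gives 168 nM.

All three share one core and differ only in the group on a saturated ring carbon. Compound 3 stands at the highest number of the three: the step of a 2.2-fold higher number from compound 1 to compound 3 (0.34 log units; beyond the scatter) and the step of a 3.0-fold higher number from compound 2 to compound 3 (0.48 log units; beyond the scatter) are both beyond the scatter, so compound 3 is the weakest inhibitor among the measured compounds. The step of a 1.4-fold lower number from compound 1 to compound 2 (0.14 log units; within the scatter), by contrast, stays within the scatter.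

Compound 4, `CN1C(=O)C(c2c(F)cccc2F)N(C)c2nc(Nc3ccc(S(N)(=O)=O)cc3)ncc21`, is not yet measured. The change from compound 3 is 2,6-difluorophenyl in place of 5-fluoro-2-methylphenyl on a saturated ring carbon. Among the measured compounds shown here, the steps that bear on it are those that swap the group on the same saturated ring carbon: the aryl-for-aryl swap a 3.0-fold higher number from compound 2 to compound 3 (0.48 log units; beyond the scatter) was modest, and the swap a 1.4-fold lower number from compound 1 to compound 2 (0.14 log units; within the scatter) gave no change beyond the scatter. For the measured compounds named here, no measured step puts two fluorine atoms on that ring, so the direction for compound 4 rests on the spread of the measured aryl analogues alone. On that basis compound 4 is expected to fall back toward the numbers of compound 1 and compound 2, a step of a 2.0-fold lower number from compound 3 to compound 4 (0.30 log units; within the scatter), with an estimate of 85 nM in this assay and a range from 30 nM to 250 nM.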

Compound 4, half-maximal inhibitory concentration: 42 nM
For compound 4 the middle estimate is 2.0-fold (0.31 log units) above the measured one; the measured number falls inside the stated range.
By their numbers in this assay, from the lowest: compounds 4, 2 and 1 (each within the scatter of the next); then compound 3.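

In this assay, replacing 5-fluoro-2-methylphenyl with 2,6-difluorophenyl on this saturated ring carbon gives a 4.0-fold lower number from compound 3 to compound 4 (0.60 log units; beyond the scatter), the largest step among the compounds shown, so this position can distinguish between two substituted phenyl groups, even though both enter with one six-membered aromatic ring of carbon only and no hydrogen-bond donors or acceptors. The other two steps, a 1.3-fold lower number from compound 2 to compound 4 (0.12 log units; within the scatter) and a 1.8-fold lower number from compound 1 to compound 4 (0.26 log units; within the scatter), stay within the scatter, so the 2,6-difluorophenyl, 2-(trifluoromethyl)phenyl and isobutyl groups cannot be told apart here, and an aryl group as such carries no penalty against isobutyl, with compound 3 alone standing at a higher number. Nothing available explains why compound 3 separates from the others.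

The aryl swaps change more than one ring substituent at a time, so the compounds shown cannot tell whether the methyl group or the placement of the fluorine goes with the higher number of compound 3. They also leave open how an unsubstituted phenyl, or a longer chain ending in an amine or a carboxylic acid, would read on this carbon.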